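A few compounds are considered here, and "the series" means these few. Any claim that something is new, unique, unknown or untested is made for them only; others in the source may bear on it.

Compound 3 `Cc1ccc(-n2cc(CNCCN3CCN(C)CC3)c(-c3ccccc3C)n2)c(C)c1` serves as the starting point of this step. In an ADME assay on Huh-7 cells (Homo sapiens) for cytotoxicity (on this read-out higher numbers stand for lower toxicity in this test and lower numbers for higher toxicity in this test), compound 3 gives > 20000 nM, which is a limit of the assay rather than a number. Its two neighbours are in the same position. Compound 1 `COc1ccc(-n2cc(CNCCN3CCN(C)CC3)c(-c3ccccc3C)n2)cc1` gives > 20000 nM in this assay, again a limit. Compound 2 `Cc1ccccc1-c1nn(-c2cc(F)ccc2F)cc1CNCCN1CCN(C)CC1` gives > 20000 nM in this assay, also a limit. The measured steps are therefore all unreadable: a step that the two limits leave unreadable from compound 1 to compound 3, a step that the two limits leave unreadable from compound 2 to compound 3 and a step that the two limits leave unreadable from compound 1 to compound 2 cannot be sized, because of the limit of > 20000 nM in this assay, at which 3 of the 3 values shown sit.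

The change that leads onward is 4-(methylsulfanyl)phenyl in place of 2,4-dimethylphenyl on an aromatic nitrogen, giving compound 4 `CSc1ccc(-n2cc(CNCCN3CCN(C)CC3)c(-c3ccccc3C)n2)cc1`. The three measured steps bear on it only in that every exchange of the group on the aromatic nitrogen so far has left the read-out at the limit, and the place of the change is the same. On that basis no step beyond the scatter is expected, so the step from compound 3 to compound 4 is estimated as a step that the limit leaves unreadable from compound 3 to compound 4. For compound 4 the expected value in this assay is 30000 nM, with a range from 10000 nM to 100000 nM, and most likely the assay will again report only a limit.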

Compound 4, half-maximal cytotoxic concentration: 17000 nM
Beside the measured number, compound 4's estimate is 1.8-fold (0.25 log units) above it; low and high end bracket the measured number.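

In this assay, compound 4 is the only one of the four compounds shown to give a number rather than a limit, so this position can bring the read-out within the range of the assay: the limit of > 20000 nM in this assay, at which 3 of the 4 values shown sit.

The limits of the other three compounds leave only floors for the change, namely an at least 1.1-fold lower number from compound 3 to compound 4 (0.07 log units; that floor lies within the scatter), an at least 1.1-fold lower number from compound 2 to compound 4 (0.07 log units; that floor lies within the scatter) and an at least 1.1-fold lower number from compound 1 to compound 4 (0.07 log units; that floor lies within the scatter). Even the narrowest exchange, methylsulfanyl in place of methoxy on an aromatic carbon, therefore cannot be sized, and none of the three steps is shown to go beyond the scatter.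

On these data alone, how far the other three compounds truly lie from compound 4 remains open, and with it whether the sulfur-bearing group has any real effect on the read-out. The compounds shown also leave open what an amine or a carboxylic acid in place of methylsulfanyl on the aromatic carbon, or a longer chain such as ethylsulfanyl, would give in this assay.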